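One Aryl Swap, Tested Again on a Second Core

The source may hold more compounds than are shown below. What is called first, only, known or untested is meant among the compounds shown, and "the series" means these compounds.

Measured in a functional assay on DU-145 cells (Homo sapiens) for inhibition, read by trypan blue exclusion, with a stated time of 96 h; on this read-out lower numbers stand for stronger inhibition of growth and higher numbers for weaker inhibition of growth:
compound 1, `CSc1ccc(/C=C(\C(=O)c2ccc(Cl)cc2)S(=O)(=O)Cc2ccc(C)cc2)cc1`, gives 10000 nM
compound 2, `Cc1ccc(CS(=O)(=O)/C(=C/c2cccc(Cl)c2Cl)C(=O)c2ccc(Cl)cc2)cc1`, gives 1000 nM
compound 3, `O=C(/C(=C\c1cccc(Cl)c1Cl)SCc1ccc(Cl)cc1)c1ccc(Cl)cc1`, gives 10000 nM

Compound 2 and compound 1 share a core and differ in one place: 4-(methylsulfanyl)phenyl in place of 2,3-dichlorophenyl on a double-bonded chain carbon bound to a double-bonded chain carbon. That change produces a 10-fold higher number from compound 2 to compound 1 (1.00 log units; beyond the scatter). Compound 3 stands on a different core, and its difference from compound 2 is not broken down here. Compound 3 and compound 1 give the same number at the digits shown, within the scatter, so no order between them can be read.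

Compound 4, `CSc1ccc(/C=C(/SCc2ccc(Cl)cc2)C(=O)c2ccc(Cl)cc2)cc1`, is not yet measured. It differs from compound 3 by 4-(methylsulfanyl)phenyl in place of 2,3-dichlorophenyl on a double-bonded chain carbon bound to a double-bonded chain carbon, the same change at the same place as before. Compound 4 is expected to show a 5.0-fold higher number from compound 3 to compound 4 (0.70 log units; beyond the scatter) in this assay, an expectation that rests on a 10-fold higher number from compound 2 to compound 1 (1.00 log units; beyond the scatter). Since compound 3 already gives the highest number seen, the expected weakening may push compound 4 past what the assay can report as a number.

The estimate for compound 4 is 50000 nM, expected to lie between 10000 nM and 200000 nM.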

Compound 4, concentration for 50% growth inhibition: 25000 nM
Estimate against measurement, compound 4: 2.0-fold (0.30 log units) above, and the stated range covers the measured number.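

In this assay, putting 4-(methylsulfanyl)phenyl in place of 2,3-dichlorophenyl on the second core gives a 2.5-fold higher number from compound 3 to compound 4 (0.40 log units; beyond the scatter), so the change points the same way on both cores. The size of the step does not carry over unchanged, and the two steps differ by more than repeat measurements would explain: the same change on two cores in this assay, a 10-fold higher number (1.00 log units; beyond the scatter) from compound 2 to compound 1 and a 2.5-fold higher number (0.40 log units; beyond the scatter) from compound 3 to compound 4, 4.0-fold (0.60 log units) apart, beyond the scatter of two such steps. This shows that the direction held on these two cores, but it gives no reason for the gap in size and does not show how the change would behave on a third core.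

Still open, going by these compounds, is how a phenyl ring bearing an amine or a carboxylic acid would compare at this place on either core.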